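Chloro for Fluoro on the Sulfonyl Ring: Expected Cytotoxicity

The source may hold more compounds than are shown below. What is called first, only, known or untested is meant among the compounds shown, and "the series" means these compounds.

Three related compounds have been measured in a functional assay on QGY-7703 cells (Homo sapiens) for cytotoxicity, read by MTT assay, with a stated time of 24 h; on this read-out lower numbers stand for stronger inhibition and higher numbers for weaker inhibition. Compound 1 `O=C1/C(=C/c2cccnc2)CN(S(=O)(=O)c2ccc(F)cc2)C/C1=C\c1ccccc1F` gives 15300 nM in this assay. Compound 2 `O=C1/C(=C/c2cccnc2)CN(S(=O)(=O)c2ccc(Cl)cc2)C/C1=C\c1ccccc1F` gives 12100 nM, and compound 3 `O=C1/C(=C/c2ccncc2)CN(S(=O)(=O)c2ccc(F)cc2)C/C1=C\c1ccccc1F` gives 9100 nM. For the measured compounds named here, all three numbers lie within the usual scatter of one another, so no compound stands apart from the others.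

Compound 2 differs from compound 1 by chloro in place of fluoro on an aromatic carbon, and this change brought a 1.3-fold lower number from compound 1 to compound 2 (0.10 log units; within the scatter). Compound 3 differs from compound 1 in how the same atoms are joined, namely (pyridin-4-yl in place of pyridin-3-yl on a double-bonded chain carbon bound to a double-bonded ring carbon), with a 1.7-fold lower number from compound 1 to compound 3 (0.23 log units; within the scatter).

Compound 4 `O=C1/C(=C/c2ccncc2)CN(S(=O)(=O)c2ccc(Cl)cc2)C/C1=C\c1ccccc1F` has not yet been measured. It differs from compound 3 by chloro in place of fluoro on an aromatic carbon. This is the same change as the one made from compound 1 to compound 2, at the same place, while the cores of the two pairs differ as described above.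

The step from compound 3 to compound 4 is therefore expected to be a 1.2-fold lower number from compound 3 to compound 4 (0.08 log units; within the scatter), resting on the earlier step of the same change, a 1.3-fold lower number from compound 1 to compound 2 (0.10 log units; within the scatter), which stayed within the scatter. Compound 4 is estimated at 7500 nM, with a range from 4000 nM to 14000 nM.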

Compound 4, half-maximal inhibitory concentration: 12500 nM
For compound 4 the middle estimate is 1.7-fold (0.22 log units) below the measured one, and the stated range covers the measured number.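

In this assay, chloro in place of fluoro gave a 1.4-fold higher number from compound 3 to compound 4 (0.14 log units; within the scatter), and this step cannot be told apart from the earlier step of the same change on the other core: the same change on two cores in this assay, a 1.3-fold lower number (0.10 log units; within the scatter) from compound 1 to compound 2 and a 1.4-fold higher number (0.14 log units; within the scatter) from compound 3 to compound 4, 1.7-fold (0.24 log units) apart, within the scatter of two such steps. Pyridin-4-yl in place of pyridin-3-yl gave a 1.0-fold higher number from compound 2 to compound 4 (0.01 log units; within the scatter), and this change likewise looks the same whichever halogen the sulfonyl ring carries: the same change on two cores in this assay, a 1.7-fold lower number (0.23 log units; within the scatter) from compound 1 to compound 3 and a 1.0-fold higher number (0.01 log units; within the scatter) from compound 2 to compound 4, 1.7-fold (0.24 log units) apart, within the scatter of two such steps. Both changes therefore stay small on both cores, but with every step inside the scatter, this does not show that either change has a real effect, and the opposite directions of the two chloro steps carry no meaning.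

What the compounds shown leave open is whether a different group on that ring, such as a methoxy group or an amine in place of the fluoro or chloro, would give a step large enough to read. From the compounds shown here alone, it is also open whether a step of that size would carry from one core to the other.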